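The source may report more compounds than this note shows. Statements on the series, on what has been measured and on what is new or still open speak of the compounds shown alone.

Measured compounds in a functional assay (aorta) with Oryctolagus cuniculus as the target; on this read-out higher numbers stand for weaker inhibition and lower numbers for stronger inhibition:
- compound 1 `OCc1ccc(-c2nn(Cc3ccccc3F)c3ncccc23)o1`, compound 1 giving 1700 nM; 1700 nM (2 entries)
- compound 2 `Cc1coc(-c2nn(Cc3ccccc3F)c3ncccc23)n1`, compound 2 giving 1200 nM
- compound 3 `Fc1ccccc1Cn1nc(C2=NCCN2)c2cccnc21`, compound 3 giving 3200 nM

Compound 3 carries the highest single number of the two available; compound 2 stands nearest, reached by a 2.7-fold higher number from compound 2 to compound 3 (0.43 log units; beyond the scatter). Compound 1 has two entries and no single number, both of which lie near the number of compound 2.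

Compound 4 `OCc1ccnc(-c2nn(Cc3ccccc3F)c3ncccc23)n1` is not yet measured. It differs from compound 3 by a group of 8 heavy atoms (5 carbon, 2 nitrogen, 1 oxygen; one six-membered aromatic ring with 2 hetero atoms) in place of a group of 5 heavy atoms (3 carbon, 2 nitrogen; one five-membered non-aromatic ring with 2 hetero atoms), on an aromatic carbon. Among the compounds with values here, the one step that bears on this is a 2.7-fold higher number from compound 2 to compound 3 (0.43 log units; beyond the scatter), where a five-membered aromatic ring gave way to a five-membered non-aromatic ring and the number rose modestly. Compound 4 reverses that sense, returning to an aromatic ring, now six-membered and bearing a hydroxymethyl as in compound 1. The expected step is therefore a 2.0-fold lower number from compound 3 to compound 4 (0.30 log units; within the scatter), a modest drop back toward the numbers of compound 1 and compound 2, though the six-membered ring is new to the series and widens the range. For compound 4 in this assay the estimate is 1600 nM, within 600 nM to 4500 nM.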

Compound 4, half-maximal inhibitory concentration: 1300 nM
The estimate for compound 4 lay 1.2-fold (0.09 log units) above the measured number, and the stated range covers the measured number.
By their numbers in this assay, from the lowest: compounds 2 and 4 (each within the scatter of the next); then compound 3.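

In this assay, a six-membered aromatic ring is tolerated on this aromatic carbon: replacing the five-membered non-aromatic ring with 4-(hydroxymethyl)pyrimidin-2-yl gives a 2.5-fold lower number from compound 3 to compound 4 (0.39 log units; beyond the scatter) and recovers what that ring had lost. Against 4-methyl-1,3-oxazol-2-yl, the same group gives a 1.1-fold higher number from compound 2 to compound 4 (0.03 log units; within the scatter) and this pair cannot be told apart on this read-out, so ring size and the change from methyl to hydroxymethyl together leave no readable mark here. Nothing on hand accounts for either step.

The compounds shown leave open what the hydroxymethyl contributes on the pyrimidine, and whether a methyl, an amine or a carboxylic acid in its place would shift the number. Also open, on these data alone, is how a plain phenyl ring would read on this aromatic carbon.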